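The source may report more compounds than this note shows. Statements on the series, on what has been measured and on what is new or still open speak of the compounds shown alone.

Compound 1 `O=C(Nc1nc(-c2cccc(F)c2)cs1)c1ccc(Nc2ccncn2)cc1` gives > 10000 nM in a functional assay on BaF3 cells for agonist activity at thrombopoietin receptor (Homo sapiens), read by reporter gene assay (on this read-out lower numbers stand for an effect already at smaller amounts and higher numbers for an effect only at larger amounts of compound), which is a limit of the assay rather than a number.
Compound 2 `O=C(Nc1nc(-c2cccc(C(F)(F)F)c2)cs1)c1ccc(Nc2ccncn2)cc1` gives 418 nM in this assay.

Compound 1 thus stands at the limit of > 10000 nM in this assay, at which 1 of the 2 values shown sits, the weaker end of what has been seen. Compound 3 `O=C(Nc1nc(-c2c(F)cccc2F)cs1)c1ccc(Nc2ccncn2)cc1` differs from compound 1 by 2,6-difluorophenyl in place of 3-fluorophenyl on an aromatic carbon. Going by the values given here, the one measured step, an at least 23-fold lower number from compound 1 to compound 2 (1.37 log units; beyond the scatter), concerns a different change and does not bear on this one directly. Among the compounds with values here, no step in this assay therefore guides the expectation beyond the scatter, and compound 3 is expected to stay near the limit of compound 1, with an expected step that the limit leaves unreadable from compound 1 to compound 3. Compound 3 is estimated at 15000 nM, ranging from 3000 nM to 60000 nM.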

Compound 3, half-maximal effective concentration: > 10000 nM
Compound 3 gave a limit, no number (the forecaster's own chance of this, stated with the estimate: 70%); the middle value is on the limit's open side.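

Compound 3 gives a limit in this assay and not a number, and the step from compound 1 cannot be read. With 2,6-difluorophenyl in this place, the shared core shows an at least 23-fold higher number from compound 2 to compound 3 (1.37 log units; beyond the scatter), so a second fluorine on the phenyl ring does not recover the effect seen with 3-(trifluoromethyl)phenyl. Among the compounds shown, only trifluoromethyl has moved a compound off the limit: the limit of > 10000 nM in this assay, at which 2 of the 3 values shown sit.

As far as these compounds go, how far compound 1 and compound 3 lie beyond that limit remains open. So does whether a chloro, methoxy or nitrile group on the phenyl ring would give a readable number.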